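The source may report more compounds than this note shows. Statements on the series, on what has been measured and on what is new or still open speak of the compounds shown alone.

In a functional assay on MOLT-4 cells (Homo sapiens) for inhibition (a higher number here means a weaker inhibitor, a lower number a stronger inhibitor), compound 3 `O=C1CCCCC/C1=C\c1ccc(F)cc1` gives 250000 nM. With hydrogen where compound 3 has fluoro, compound 2 `O=C1CCCCC/C1=C\c1ccccc1` gives 215000 nM, and the two values lie within the scatter of each other. Compound 1 `Cc1cccc(/C=C2\CCCc3ccccc3C2=O)c1`, built on a different core, gives 34600 nM, a clearly lower number than that of compound 3. Compound 3 therefore sits at the weak end of this small set, level with compound 2.

The next compound is compound 4 `O=C1CCCCC/C1=C\c1ccc(Br)cc1`, with bromo in place of fluoro on an aromatic carbon. Going by the values given here, only one measured step bears directly on this change, the replacement of hydrogen by fluoro on an aromatic carbon, which gave a 1.2-fold higher number from compound 2 to compound 3 (0.07 log units; within the scatter). Among the compounds with values here, that step lies within the scatter, but it is a single example, and no bromo compound has yet been measured. The data therefore give no firm reason to expect a shift in either direction, although the lower value of compound 1 leaves some room for a lower number. The expected result is a 1.4-fold lower number from compound 3 to compound 4 (0.14 log units; within the scatter), which would be no real change beyond the scatter. For compound 4, the estimated value in this assay is 180000 nM, with an expected range from 80000 nM to 350000 nM.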

Compound 4, half-maximal inhibitory concentration: 49400 nM
Compound 4: the middle estimate sits 3.6-fold (0.56 log units) above what was measured; measured number outside the range, below it.
By their numbers in this assay, from the lowest: compounds 1 and 4 (each within the scatter of the next); then compounds 2 and 3 (each within the scatter of the next).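

In this assay, the group para to a group of 9 heavy atoms on the six-membered aromatic ring proves able to move the number, which the hydrogen-to-fluoro step alone had not shown: bromo in place of fluoro gives a 5.1-fold lower number from compound 3 to compound 4 (0.70 log units; beyond the scatter), and bromo in place of hydrogen gives a 4.4-fold lower number from compound 2 to compound 4 (0.64 log units; beyond the scatter). Both steps lie beyond the scatter, while fluoro and hydrogen stay within the scatter of each other, so at this position on the shared core, the two halogens, each a single heavy atom with no hydrogen-bond donors or acceptors counted, do not read alike. No measurement presented here accounts for this difference between bromo and fluoro.

The compounds shown leave open whether the lower number is particular to bromo or would also appear with chloro, iodo, methyl or methoxy at the same position. They also leave open whether bromo would bring a step of similar size on the core of compound 1.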